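Quinazoline anilines with macrocyclic amine tails: aryl swap

The compounds below may be only part of what the source reports. "The series", "measured", "known", "first", "only" and "open" are said of these compounds alone.

Compound 1 `COc1cc2ncnc(Nc3ccc(Cl)cc3Cl)c2cc1OCCCN1CCNCCNCCNCC1` carries a 2,4-dichlorophenyl on the aniline nitrogen and a macrocyclic amine ring at the end of the propoxy chain. In a functional assay on A549 cells (Homo sapiens) for antiproliferative activity, read by MTT assay, with a stated time of 72 h (a higher number here means a weaker inhibitor, a lower number a stronger inhibitor), compound 1 gives 23800 nM. Compound 2 `COc1cc2ncnc(Nc3ccc(C#N)cc3F)c2cc1OCCCN1CCNCCNCCNCC1` differs from compound 1 by 4-cyano-2-fluorophenyl in place of 2,4-dichlorophenyl on a nitrogen on an aromatic ring. In this assay compound 2 is reported only as a limit of the assay, > 50000 nM; this is the limit described in the limit of > 50000 nM in this assay, at which 1 of the 3 values shown sits, and not a number. The change produces an at least 2.1-fold higher number from compound 1 to compound 2 (0.32 log units; beyond the scatter).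

Compound 3 `COc1cc2ncnc(Nc3ccc(Cl)cc3Cl)c2cc1OCCCN1CCNCCNCC1` shares the aniline of compound 1; the two cores differ as a group of 9 heavy atoms (6 carbon, 3 nitrogen; one nine-membered non-aromatic ring with 3 hetero atoms) in place of a group of 12 heavy atoms (8 carbon, 4 nitrogen; one twelve-membered non-aromatic ring with 4 hetero atoms), on a saturated chain carbon, three bonds along the chain from an oxygen on an aromatic ring. In this assay compound 3 gives 44200 nM, and the core change makes a 1.9-fold higher number from compound 1 to compound 3 (0.27 log units; within the scatter), so compound 1 and compound 3 are not separated here.

Compound 4 `COc1cc2ncnc(Nc3ccc(C#N)cc3F)c2cc1OCCCN1CCNCCNCC1` has not yet been measured in this assay. Within the data shown here, it differs from compound 3 by 4-cyano-2-fluorophenyl in place of 2,4-dichlorophenyl on a nitrogen on an aromatic ring, which is the same change, at the same place, as the one from compound 1 to compound 2. Compound 4 is expected to show a step of about a 2.5-fold higher number from compound 3 to compound 4 (0.40 log units; beyond the scatter) in this assay, matching or exceeding the earlier one, because the earlier step of an at least 2.1-fold higher number from compound 1 to compound 2 (0.32 log units; beyond the scatter) ran into the limit (the limit of > 50000 nM in this assay, at which 1 of the 3 values shown sits). Compound 3 starts from 44200 nM. For compound 4 the value in this assay is estimated at 110000 nM, between 50000 nM and 300000 nM, most likely reported as the limit rather than a number.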

Compound 4, half-maximal inhibitory concentration: > 50000 nM
Compound 4 ended at the assay's limit (the forecaster's own chance of this, stated with the estimate: 85%); the middle value lies beyond the limit too.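

In this assay compound 4 is reported as > 50000 nM, which is a limit of the assay and not a number. Carried onto the core with the nine-membered ring, the swap from 2,4-dichlorophenyl to 4-cyano-2-fluorophenyl yields only a floor, an at least 1.1-fold higher number from compound 3 to compound 4 (0.05 log units; that floor lies within the scatter), so the notes can record that the change gives no measured number on either core, but not that it has the same size on both: the same change on two cores in this assay, an at least 2.1-fold higher number (0.32 log units; beyond the scatter) from compound 1 to compound 2 and an at least 1.1-fold higher number (0.05 log units; that floor lies within the scatter) from compound 3 to compound 4; the limit leaves it open whether they differ The step from compound 2 to compound 4 cannot be read either, so these compounds show nothing about ring size in the tail when the aniline carries 4-cyano-2-fluorophenyl: the limit of > 50000 nM in this assay, at which 2 of the 4 values shown sit.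

Still open, going by these compounds, is the real size of the swap on each core, and whether it would hold with a tail of another kind, such as an open-chain amine or a morpholine in place of the macrocyclic ring. Also open, on these data alone, is how the change would divide up in anilines carrying a single group, such as 4-chlorophenyl or 2-fluorophenyl.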